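Sulfoxide anilides in the cyanovinyl quinazoline series: cytotoxicity

A few compounds are considered here, and "the series" means these few. Any claim that something is new, unique, unknown or untested is made for them only; others in the source may bear on it.

Measured compounds:
compound 1 `COc1cc2nc(Nc3ccc(C#N)cc3)nc(Nc3c(Cl)cc(/C=C/C#N)cc3Cl)c2cc1OC`, 9920 nM
compound 2 `COc1cc2nc(SCC(=O)Nc3ccc(C(F)(F)F)cc3)nc(Nc3c(C)cc(/C=C/C#N)cc3C)c2cc1OC`, > 211000 nM
compound 3 `COc1cc2nc([S+]([O-])CC(=O)Nc3cccc(C(F)(F)F)c3)nc(Nc3c(Cl)cc(/C=C/C#N)cc3Cl)c2cc1OC`, 21800 nM

In an ADME assay on MT4 cells (Homo sapiens) for cytotoxicity, read by MTT assay, with a stated time of 5 days (a higher number here means that more compound is tolerated, a lower number that less compound is tolerated), compound 3 gives the higher of the two numbers; compound 1 sits a step below it, beyond the usual scatter. For compound 2 the result is only a limit of the assay, (the limit of > 211000 nM in this assay, at which 1 of the 3 values shown sits), not a number. Compound 4 `COc1cccc(NC(=O)C[S+]([O-])c2nc(Nc3c(Cl)cc(/C=C/C#N)cc3Cl)c3cc(OC)c(OC)cc3n2)c1` is the next entry for this assay. It differs from compound 3 by methoxy in place of trifluoromethyl on an aromatic carbon. Within the data shown here, no measured pair separates this change on its own, so the step from compound 3 to compound 4 is expected to be small, in either direction, and not beyond the scatter: a 1.0-fold higher number from compound 3 to compound 4 (0.00 log units; within the scatter). Compound 4 is therefore estimated at 22000 nM, with a range from 8000 nM to 65000 nM.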

Compound 4, half-maximal cytotoxic concentration: >= 167000 nM
Compound 4 gave a limit, no number; the forecaster's own chance of this, stated with the estimate: 15%; at least 7.5-fold (0.88 log units) between middle value and limit.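

In this assay, methoxy in place of trifluoromethyl on this aromatic carbon gives an at least 7.6-fold higher number from compound 3 to compound 4 (0.88 log units; beyond the scatter). This first single-place step in the series shows that this one group on the anilide ring can move the read-out beyond the scatter, with the sulfoxide and the shared core unchanged. Compound 4 gives a limit of the assay, not a number: the limit of >= 167000 nM in this assay, at which 1 of the 4 values shown sits.

As far as these compounds go, the upper end of the step stays open. Also open, from the compounds shown here alone, is how an amine or a carboxylic acid on this same carbon would read in this assay.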